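Three Inactive Dinitro and Nitro Triazoles, and a Fourth

The source may hold more compounds than are shown below. What is called first, only, known or untested is meant among the compounds shown, and "the series" means these compounds.

The read-out throughout is an ADME assay on A-431 cells (Homo sapiens) for cytotoxicity, with a stated time of 48 h; a lower number here means a stronger inhibitor, a higher number a weaker inhibitor. Compound 1 `COc1ccc(CSc2nnc(-c3cc([N+](=O)[O-])cc([N+](=O)[O-])c3)n2Cc2ccccc2)cc1` is the starting point. In this assay compound 1 reaches only the limit of the measurement, > 30000 nM. Compound 2 `O=[N+]([O-])c1cc(-c2nnc(SCc3ccc(Cl)cc3)n2Cc2ccccc2)cc([N+](=O)[O-])c1` carries the change (chloro in place of methoxy on an aromatic carbon). In this assay compound 2 likewise stops at a limit, > 30000 nM. Compound 3 `COc1ccc(CSc2nnc(-c3cc([N+](=O)[O-])cc(C(F)(F)F)c3)n2Cc2ccccc2)cc1` differs from compound 1 by trifluoromethyl in place of nitro on an aromatic carbon. In this assay compound 3 also gives a limit, > 30000 nM. Because (the limit of > 30000 nM in this assay, at which 3 of the 3 values shown sit), the steps a step that the two limits leave unreadable from compound 1 to compound 2 and a step that the two limits leave unreadable from compound 1 to compound 3 cannot be sized.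

Compound 4 `O=[N+]([O-])c1cc(-c2nnc(SCc3ccc(Cl)cc3)n2Cc2ccccc2)cc(C(F)(F)F)c1` has not yet been measured. It differs from compound 3 by chloro in place of methoxy on an aromatic carbon. The same change was already made from compound 1 to compound 2, where the two limits left the step that the two limits leave unreadable from compound 1 to compound 2 unreadable. The cores of compound 3 and compound 4 differ from those of compound 1 and compound 2 by the change (trifluoromethyl in place of nitro on an aromatic carbon), which is the difference from compound 1 to compound 3.

Within the data shown here, with every value so far resting at the limit, the step from compound 3 to compound 4 in this assay is expected to be a step that the limit leaves unreadable from compound 3 to compound 4, because the limit of > 30000 nM in this assay, at which 3 of the 3 values shown sit, offers nothing pointing elsewhere. For compound 4 in this assay the estimate is 40000 nM, expected to lie between 15000 nM and 120000 nM, most likely again reported only as a limit.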

Compound 4, half-maximal inhibitory concentration: > 30000 nM
Compound 4: no number, only a limit (the forecaster's own chance of this, stated with the estimate: 85%); the middle value lies beyond the limit too.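

In this assay compound 4 gives > 30000 nM, a limit and not a number. The steps to compound 4 from compound 2 and from compound 3 therefore cannot be read, for the same reason as the earlier steps: the limit of > 30000 nM in this assay, at which 4 of the 4 values shown sit. On these data alone, whether chloro in place of methoxy, or trifluoromethyl in place of nitro, changes the response in this assay at all remains open.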